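This account rests on a few compounds, and the source may have more. Where it says the series, first, only, none or still open, it means among the compounds named here.

Working notes on the series. Among the measured compounds shown here, in a functional assay on MCF7 cells (Homo sapiens) for inhibition, read by MTT assay, with a stated time of 72 h (on this read-out lower numbers stand for stronger inhibition and higher numbers for weaker inhibition), compound 1 (`COc1cccc(NC(=O)C2CCN(C/C=C/c3ccccc3)CC2)c1`) gives 42700 nM and compound 2 (`O=C(Nc1cccc(Br)c1)C1CCN(C/C=C/c2ccccc2)CC1`) gives 11500 nM as the lower of the two numbers so far. For the measured compounds named here, the only measured step (a 3.7-fold lower number from compound 1 to compound 2 (0.57 log units; beyond the scatter)) is modest but beyond the scatter, with bromo in place of methoxy on an aromatic carbon.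

Compound 3 (`O=C(NCc1ccccc1)C1CCN(C/C=C/c2ccccc2)CC1`) differs from compound 2 at the amide: benzyl in place of 3-bromophenyl on an amide-type nitrogen describes benzyl in place of 3-bromophenyl on an amide-type nitrogen. Going by the values given here, no measured compound carries benzyl, so the one step bears on this change only loosely. Among the compounds with values here, it shows that a change to the group on this nitrogen can shift the number modestly, and compound 1, the only measured compound without bromine, stands at 42700 nM on the weaker side. A modest step towards a higher number is therefore expected in this assay, though a step within the scatter remains possible. The expected step is (a 2.4-fold higher number from compound 2 to compound 3 (0.39 log units; beyond the scatter)) on this estimate. For compound 3 the estimated value is 28000 nM with an expected range from 10000 nM to 75000 nM as its limits.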

Compound 3, half-maximal inhibitory concentration: > 100000 nM
Compound 3: a limit, no number; the forecaster's own chance of this, stated with the estimate: 15%; at least 3.5-fold (0.55 log units) between middle value and limit.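

In this assay compound 3 stands at a limit of the assay and not at a number: the limit of > 100000 nM in this assay, at which 1 of the 3 values shown sits.

Benzyl in place of 3-bromophenyl on an amide-type nitrogen gives an at least 8.6-fold higher number from compound 2 to compound 3 (0.93 log units; beyond the scatter), and benzyl in place of 3-methoxyphenyl at the same place gives an at least 2.3-fold higher number from compound 1 to compound 3 (0.36 log units; beyond the scatter); both are beyond the scatter, and each gives only a bound on the size of the step. The earlier pair showed only a swap of bromo for methoxy on an aromatic carbon, whereas this result shows that replacing the whole group on this nitrogen with benzyl moves the number towards weaker inhibition from both compound 1 and compound 2.

As far as these compounds go, how far compound 3 lies past its limit stays open, so the true size of both steps is unknown. Benzyl also differs from 3-bromophenyl and 3-methoxyphenyl in more than one feature, so the compounds shown leave open whether an unsubstituted phenyl, a 3-bromobenzyl or a longer chain such as 2-phenylethyl on this nitrogen would stay in the range of compound 2 or fall with compound 3.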